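A few compounds are considered here, and "the series" means these few. Any claim that something is new, unique, unknown or untested is made for them only; others in the source may bear on it.

In a functional assay on HL-60 cells (Homo sapiens) for inhibition, read by MTT assay, with a stated time of 72 h (on this read-out higher numbers stand for weaker inhibition and lower numbers for stronger inhibition), compound 1 (`CCc1nc(-c2ccccc2F)c(C(=O)N2CCN(c3cccc(Cl)c3)CC2)o1`) gives 139 nM and stands within the scatter of the other two measured compounds. Compound 2 (`Cc1nc(-c2ccccc2F)c(C(=O)N2CCN(c3cc(Cl)ccc3C)CC2)o1`) gives 229 nM and compound 3 (`CCOc1cccc(N2CCN(C(=O)c3oc(C)nc3-c3ccccc3)CC2)c1`) gives 151 nM in the same test, so no order can be read among the three. Compound 4 (`CCc1nc(-c2cccc(F)c2)c(C(=O)N2CCN(c3cccc(Cl)c3)CC2)o1`) differs from compound 1 by carrying 3-fluorophenyl in place of 2-fluorophenyl on an aromatic carbon. Within the data shown here, no measured pair differs in one place, so the data offer no direct guide to this change. In this assay no step beyond the scatter is expected, with only a slight drift towards a higher number. The estimated change is a 1.2-fold higher number from compound 1 to compound 4 (0.07 log units; within the scatter) and remains a working expectation. For compound 4 the estimated value is 165 nM (expected range 65 nM to 420 nM).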

Compound 4, half-maximal inhibitory concentration: 317 nM
Estimate against measurement, compound 4: 1.9-fold (0.28 log units) below; low and high end bracket the measured number.
By their numbers in this assay, from the lowest: compounds 1, 3, 2 and 4 (each within the scatter of the next, the first and the last beyond it).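

Moving the fluorine from 2-fluorophenyl to 3-fluorophenyl gives the first one-place comparison in the series: in this assay, the change is a 2.3-fold higher number from compound 1 to compound 4 (0.36 log units; beyond the scatter). This position therefore responds to where a single fluorine sits, even though the two compounds hold the same atoms. Nothing available accounts for the step.

Still open, going by these compounds, is whether a nitrile or trifluoromethyl in place of the fluorine would give a similar step. On these data alone, whether the step holds with other groups on the shared core also remains open.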